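A few compounds are considered here, and "the series" means these few. Any claim that something is new, unique, unknown or untested is made for them only; others in the source may bear on it.

Measured so far in a physicochemical assay for lipophilicity, read by HPLC, at pH 7.4; a higher number here means a more lipophilic compound, a lower number a more polar compound:
- compound 1 `COc1ccc(-c2cc(-c3ccc(S(C)(=O)=O)cc3)cnc2N)cn1`: 2.2
- compound 2 `Cc1ccc(-c2cc(-c3ccc(S(C)(=O)=O)cc3)cnc2N)cn1`: 1.8

Of these two, compound 2 holds the lower number at 1.8, and the gap to compound 1 lies beyond the scatter. Compound 3 `CS(=O)(=O)c1ccc(-c2cnc(N)c(-c3ccc(CO)nc3)c2)cc1` has not yet been measured. It differs from compound 2 in one place: hydroxy in place of hydrogen on a saturated chain carbon bound to an aromatic carbon. This is hydroxy in place of hydrogen on a saturated chain carbon bound to an aromatic carbon, so methyl becomes hydroxymethyl.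

Within the data shown here, only one measured step offers any guide in this assay: a number 0.40 log units lower from compound 1 to compound 2 (beyond the scatter), with methyl in place of methoxy on an aromatic carbon. Among the measured compounds shown here, this step is modest and is not the same change, and no measured pair shows the entry of a hydroxy group. Its size therefore serves only as a loose yardstick, and the direction expected here rests on the structural change itself. A lower number is expected, by more than that measured step. The estimated change is a number 0.70 log units lower from compound 2 to compound 3 (beyond the scatter). For compound 3 the estimate is 1.1, with an expected range of 0.6 to 1.6.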

Compound 3, distribution coefficient: 1.2
Compound 3: the middle estimate sits 0.10 log units below what was measured; low and high end bracket the measured number.
By their numbers in this assay, from the lowest: compound 3; then compound 2; then compound 1.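

In this assay, among these compounds, turning methyl into hydroxymethyl gives a number 0.60 log units lower from compound 2 to compound 3 (beyond the scatter), which is the only measured step here that brings a hydroxy group onto the saturated chain carbon bound to an aromatic carbon. Against methoxy, hydroxymethyl gives a number 1.00 log units lower from compound 1 to compound 3 (beyond the scatter), so the three groups shown now run hydroxymethyl, methyl, methoxy from the lowest number to the highest, with every step between them beyond the scatter. The compounds show the size and direction of these steps, but no supporting measurement accounts for them.

Going by these compounds, because the series holds a single hydroxy-bearing compound on a single shared core, it remains open whether the step in this assay depends on the free hydroxy group or would also follow from an oxygen on this chain carbon in another form. Methoxymethyl would bear on that question, while aminomethyl, a carboxylic acid or a longer chain such as 2-hydroxyethyl would show how far the step extends to other groups at this place.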